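This account rests on a few compounds, and the source may have more. Where it says the series, first, only, none or still open, it means among the compounds named here.

Working notes on the series in a functional assay on DU-145 cells (Homo sapiens) for antiproliferative activity, read by MTT assay, with a stated time of 48 h; a lower number here means a stronger inhibitor, a higher number a weaker inhibitor. Compound 1 `c1ccc(-c2nnc(-c3cn4ccccc4n3)o2)cc1` gives 23400 nM and compound 2 `Clc1ccc(-c2nnc(-c3cn4ccccc4n3)o2)cc1` gives 32800 nM. Among the compounds with values here, compound 2 therefore stands within the scatter of compound 1, the only other compound measured so far. Next is compound 3 `COc1ccc(-c2nnc(-c3cn4ccccc4n3)o2)cc1`, with the change (methoxy in place of chloro on an aromatic carbon), in words methoxy in place of chloro on an aromatic carbon. Within the data shown here, no measured compound carries methoxy, so the only guide is the single measured step at this ring, chloro in place of hydrogen on an aromatic carbon: a 1.4-fold higher number from compound 1 to compound 2 (0.15 log units; within the scatter). On these data alone, on the strength of that small step, no change beyond the scatter is expected in this assay, and the direction stays open. The expected step is a 1.3-fold lower number from compound 2 to compound 3 (0.10 log units; within the scatter). For compound 3 the estimate is 26000 nM, with an expected range of 12000 nM to 60000 nM.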

Compound 3, half-maximal inhibitory concentration: 12900 nM
For compound 3 the middle estimate is 2.0-fold (0.30 log units) above the measured one; the measured number falls inside the stated range.
By their numbers in this assay, from the lowest: compounds 3, 1 and 2 (each within the scatter of the next, the first and the last beyond it).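

Within the data shown here, at this position, on an aromatic carbon para to a large group, methoxy in place of chloro gives the first step in this assay that lies beyond the scatter (a 2.5-fold lower number from compound 2 to compound 3 (0.41 log units; beyond the scatter)). Methoxy in place of hydrogen does not clear the scatter (a 1.8-fold lower number from compound 1 to compound 3 (0.26 log units; within the scatter)), so the separation appears only between the two substituted compounds, while compound 1 stays within the scatter of both. Nothing available here bears on why methoxy and chloro differ at this position.

On these data alone, whether the separation extends to other groups at this position, such as an amine, a carboxylic acid or a longer alkoxy chain, stays open. As far as these compounds go, all three compounds vary at this one position only, so the effect of a change elsewhere on the shared core in this assay also stays open.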